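Weak point of the series and a ring swap at the amine

The source may hold more compounds than are shown below. What is called first, only, known or untested is meant among the compounds shown, and "the series" means these compounds.

Compound 2 `COc1cc(CNCCSc2nnnn2C)ccc1OCc1ccc(Cl)nc1` gives the highest of the two numbers shown: in a functional assay on HeLa cells (Homo sapiens) for inhibition, with a stated time of 72 h (a higher number here means that more compound is needed for the effect, a lower number that less compound is needed), compound 2 gives 86000 nM, while compound 1 `COc1cc(CNCc2ccncc2)ccc1OCc1ccc([N+](=O)[O-])cc1` gives 440 nM, a gap that is beyond the usual scatter. Compound 3 `COc1cc(CNCC2CCCO2)ccc1OCc1ccc(Cl)nc1` keeps the core of compound 2 and differs from it in one place: oxolan-2-yl in place of ((1-methyl-1H-tetrazol-5-yl)sulfanyl)methyl on a saturated chain carbon bound to an amine nitrogen. The oxolan-2-yl group is the smaller of the two, and the five-membered aromatic ring with its four hetero atoms is gone. Among the compounds with values here, no measured pair shows this change, so the direction and size of the step are open. The step from compound 2 to compound 3 is expected to be modest, with the number coming down somewhat, a 2.2-fold lower number from compound 2 to compound 3 (0.33 log units; beyond the scatter), though a change within the scatter is also plausible. For compound 3 the value in this assay is estimated at 40000 nM, with a likely range from 8000 nM to 200000 nM.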

Compound 3, half-maximal effective concentration: 66000 nM
Beside the measured number, compound 3's estimate is 1.7-fold (0.22 log units) below it; the measured number falls inside the stated range.
By their numbers in this assay, from the lowest: compound 1; then compounds 3 and 2 (each within the scatter of the next).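

In this assay, within the data shown here, the swap to oxolan-2-yl on a saturated chain carbon bound to an amine nitrogen gives a 1.3-fold lower number from compound 2 to compound 3 (0.11 log units; within the scatter), the first single-place reading at this position. With the rest of the core held, the ((1-methyl-1H-tetrazol-5-yl)sulfanyl)methyl group, with its five-membered aromatic ring bearing 4 hetero atoms, can give way to a group of 5 heavy atoms without a change that can be read in this assay. No measurement at hand explains this result.

Going by these compounds, whether an amine, a carboxylic acid or a longer chain at this place would move the number remains open. Compound 1 differs from compound 2 and compound 3 in more than one place, so what separates it from them cannot be read from these compounds.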